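The source may hold more compounds than are shown below. What is called first, only, known or untested is meant among the compounds shown, and "the series" means these compounds.

Measured in a physicochemical assay for solubility, with a stated time of 24 h, tested at 30 mg/mL; on this read-out lower numbers stand for lower solubility and higher numbers for higher solubility:

- compound 1 `CCCCN1CC(CC(=O)NO)(NS(=O)(=O)c2ccc(OCc3cc(C)nc4ccccc34)cc2)C1`: 4900000 nM
- compound 2 `Cc1cc(COc2ccc(S(=O)(=O)NC3(CC(=O)NO)CN(C(=O)N4CCCCC4)C3)cc2)c2ccccc2n1`: 500000 nM

For the measured compounds named here, of these two compounds, compound 2 has the lower number, and compound 1 is its only neighbour on the scale. The next compound to be tested is compound 3 `Cc1cc(COc2ccc(S(=O)(=O)NC3(CC(=O)NO)CN(C(=O)C(C)(C)N(C)C)C3)cc2)c2ccccc2n1`. It has 1-(dimethylamino)-1-methylethyl in place of piperidin-1-yl on a carbonyl carbon. The carbonyl stays, and only the group attached to it changes.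

Going by the values given here, one measured step bears on this change: a 9.8-fold lower number from compound 1 to compound 2 (0.99 log units; beyond the scatter). That step put (piperidin-1-yl)carbonyl in place of butyl on an amine nitrogen in a ring, so it involves the same part of the molecule. Among the compounds with values here, it is only a loose guide, since no measured compound carries the 1-(dimethylamino)-1-methylethyl group. Compound 2 sits at the low end of the two values, and compound 1 at 4900000 nM shows that a higher number is reachable with the same core. A step upward in this assay is therefore expected, somewhat smaller than the measured one. The expected step is a 4.0-fold higher number from compound 2 to compound 3 (0.60 log units; beyond the scatter). For compound 3 the estimated value is 2000000 nM, with an expected range of 400000 nM to 10000000 nM.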

Compound 3, solubility: 11000000 nM
Estimate against measurement, compound 3: 5.5-fold (0.74 log units) below; the whole stated range lies below it.
By their numbers in this assay, from the lowest: compound 2; then compound 1; then compound 3.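

Compound 3 keeps the carbonyl of compound 2, and the group on it has the same count of 6 heavy atoms (5 carbon, 1 nitrogen), yet this assay shows a 22-fold higher number from compound 2 to compound 3 (1.34 log units; beyond the scatter), so a large shift arises here from replacing the piperidin-1-yl ring with the open-chain 1-(dimethylamino)-1-methylethyl group. The earlier fall on moving from butyl to (piperidin-1-yl)carbonyl therefore does not hold for every carbonyl group at this ring nitrogen, since this assay gives a 2.2-fold higher number from compound 1 to compound 3 (0.35 log units; beyond the scatter), placing the new carbonyl compound above the butyl compound. No measurement on hand gives a reason for this shift.

Going by these compounds, what remains open is whether the missing ring, the branched carbon or the dimethylamino group accounts for the difference, as all of these change together between compound 2 and compound 3. A tert-butyl group on the carbonyl, which has the branched carbon but no amine, and a piperidine ring carrying a dimethylamino group, which has both ring and amine, would help separate these possibilities.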